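Replacing the 5-chlorothiophen-2-yl group of compound 3 with methyl

This account rests on a few compounds, and the source may have more. Where it says the series, first, only, none or still open, it means among the compounds named here.

Values so far in a functional assay on HCT-116 cells (Homo sapiens) for cytotoxicity, read by MTT assay, with a stated time of 48 h, in the presence of a further agent that is not named here (on this read-out lower numbers stand for an effect already at smaller amounts and higher numbers for an effect only at larger amounts of compound), are these
compound 1 `Cc1nn(C)c2nc(NNC(=O)Nc3cc(Cl)nc(Cl)c3)cc(-c3ccco3)c12` gives 69200 nM
compound 2 `Cc1nn(C)c2nc(NNC(=O)Nc3cc(Cl)nc(Cl)c3)cc(C3CCCCC3)c12` gives 38000 nM
compound 3 `Cc1nn(C)c2nc(NNC(=O)Nc3cc(Cl)nc(Cl)c3)cc(-c3ccc(Cl)s3)c12` gives 42100 nM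

Compound 3 cannot be told apart from the other two, with a 1.1-fold higher number from compound 2 to compound 3 (0.04 log units; within the scatter) and a 1.6-fold lower number from compound 1 to compound 3 (0.22 log units; within the scatter) both lying within the scatter. Compound 4 `Cc1cc(NNC(=O)Nc2cc(Cl)nc(Cl)c2)nc2c1c(C)nn2C` has yet to be measured. It carries methyl in place of 5-chlorothiophen-2-yl on an aromatic carbon at the place where the three measured compounds differ. The steps at that place are small, with a 1.8-fold lower number from compound 1 to compound 2 (0.26 log units; within the scatter) the largest. For the measured compounds named here, none of the measured compounds carries methyl there, so the expectation remains loose. No step beyond the scatter is expected in this assay in either direction, and the expected step is a 1.2-fold higher number from compound 3 to compound 4 (0.07 log units; within the scatter) on this estimate. Compound 4 is estimated at 50000 nM with an expected range from 25000 nM to 100000 nM in this measurement.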

Compound 4, half-maximal effective concentration: > 100000 nM
Compound 4: no number, only a limit; the forecaster's own chance of this, stated with the estimate: 10%; middle value at least 2.0-fold (0.30 log units) away from the limit.
By their numbers in this assay, from the lowest: compounds 2, 3 and 1 (each within the scatter of the next). At a limit, above all of these: compound 4.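

In this assay compound 4 gives only a limit of the assay, not a number: the limit of > 100000 nM in this assay, at which 1 of the 4 values shown sits. This position does respond to change, since methyl in place of 5-chlorothiophen-2-yl gives an at least 2.3-fold higher number from compound 3 to compound 4 (0.37 log units; beyond the scatter) and methyl in place of cyclohexyl gives an at least 2.6-fold higher number from compound 2 to compound 4 (0.42 log units; beyond the scatter), whereas the steps among the three earlier groups stayed within the scatter. Methyl in place of furan-2-yl gives an at least 1.4-fold higher number from compound 1 to compound 4 (0.15 log units; that floor lies within the scatter), so this pair remains unseparated. The compounds shown leave open the true value of compound 4. They also leave open whether a longer chain such as butyl, or an amine, on this aromatic carbon would match compound 2 and compound 3.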